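Efficacy notes: ring swap on the carbonyl carbon

A few compounds are considered here, and "the series" means these few. Any claim that something is new, unique, unknown or untested is made for them only; others in the source may bear on it.

Measured so far in a functional assay on isolated protein for inhibition of Glucose-dependent insulinotropic receptor (Rattus norvegicus), read by HTRF and cAMP accumulation; on this read-out lower numbers stand for smaller maximal responses and higher numbers for larger maximal responses:
compound 1 `Cc1nc(S(C)(=O)=O)ccc1Oc1ncnc(OC2CCN(C(=O)OC(C)F)CC2)c1F`, 68%
compound 2 `Cc1nc(S(C)(=O)=O)ccc1Oc1ncnc(OC2CCN(C(=O)OC3COC3)CC2)c1F`, 66%
compound 3 `Cc1nc(S(C)(=O)=O)ccc1Oc1ncnc(OC2CCN(C(=O)C(F)(F)F)CC2)c1F`, 76%

Compound 2 differs from compound 1 by a number 2 percentage points lower from compound 1 to compound 2 (within the scatter) and from compound 3 by a number 10 percentage points higher from compound 2 to compound 3 (within the scatter); all three values sit within the scatter of one another. Compound 4 `Cc1nc(S(C)(=O)=O)ccc1Oc1ncnc(OC2CCN(C(=O)C3(F)CCC3)CC2)c1F` changes compound 2 on the carbonyl carbon whose other neighbour is an amide-type nitrogen in a ring: a group of 5 heavy atoms (4 carbon, 1 fluorine; one four-membered non-aromatic ring of carbon only) in place of a group of 5 heavy atoms (3 carbon, 2 oxygen; one four-membered non-aromatic ring with 1 hetero atom), on a carbonyl carbon. Among the measured compounds shown here, the steps that bear on this are a number 10 percentage points higher from compound 2 to compound 3 (within the scatter) and a number 8 percentage points higher from compound 1 to compound 3 (within the scatter), where a carbon- and fluorine-bearing group likewise took the place of an oxygen-bearing group on that carbonyl carbon; both were within the scatter. No step beyond the scatter is therefore expected in this assay for compound 4, and the expected step is a number 5 percentage points higher from compound 2 to compound 4 (within the scatter). Compound 4 is estimated at 71%, range 59% to 83%.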

Compound 4, largest response reached (reported as efficacy), in percent of the reference or control that the assay uses: 91%
Compound 4: middle estimate off by 20 percentage points, on the low side; measured number outside the range, above it.
By their numbers in this assay, from the lowest: compounds 2, 1 and 3 (each within the scatter of the next); then compound 4.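

In this assay the carbonyl carbon whose other neighbour is an amide-type nitrogen in a ring now gives steps beyond the scatter, which no earlier swap there gave: a number 25 percentage points higher from compound 2 to compound 4 (beyond the scatter) and a number 23 percentage points higher from compound 1 to compound 4 (beyond the scatter) and also a number 15 percentage points higher from compound 3 to compound 4 (beyond the scatter). Compound 4 therefore stands apart from all three earlier groups, which stay within the scatter of one another. No measurement at hand accounts for this step. Open, on these data alone, is whether the ring or the fluorine carries it: a plain cyclobutyl group on the same carbonyl carbon would separate the two.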